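The source may report more compounds than this note shows. Statements on the series, on what has been measured and on what is new or still open speak of the compounds shown alone.

Measured so far:
compound 1, `O=C1Cc2cc(OCCc3ccc(F)cc3)ccc2N1`, in an assay on cells for inhibition of Amine oxidase [flavin-containing] B (Homo sapiens), read by fluorescence, with stated times of 30 min and 15 min, tested at 1 uM (a lower number here means less inhibition, a higher number more inhibition at the concentration tested (going by the name of the read-out)), gives 18.1%.
compound 2, `Cn1c(=O)[nH]c2cc(OCc3ccccc3)ccc21`, is reported in this assay as "not active" (no number reported), without a number.
compound 3, `Cn1c(=O)[nH]c2ccc(OCc3cccc(F)c3)cc21`, in this assay gives 5.36%.

Compound 3 holds the lowest of the two numbers that exist. Its nearest neighbour is compound 1, whose number lies higher by a gap larger than the usual scatter of such measurements. Compound 2, which carries the same core as compound 3 with the side chain attached at a different position, came out without any number at all and is reported as not active.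

Compound 4, `Cn1c(=O)[nH]c2ccc(OCc3ccccc3)cc21`, has not yet been measured in this assay. Compared with compound 3 it differs in one spot: hydrogen in place of fluoro on an aromatic carbon. The change is small in size. Among the compounds with values here, nothing among the measured compounds shows what removing a fluoro does on this core; no pair differing only in that way has been measured.

Given that compound 3 already sits near the bottom of the scale, compound 4 is expected to stay in the same low region. The step from compound 3 to compound 4 is estimated at a number 2.4 percentage points lower from compound 3 to compound 4 (within the scatter), which is no larger than the scatter. Compound 4 is therefore expected to give about 3%, within a range from -6% to 12%.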

Compound 4, a percentage reported as inhibition, at one concentration (the size of the read-out at that concentration, not a potency): "not active" (no number reported)
Compound 4: no number reported, so the estimate cannot be set against anything.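

Compound 4 is reported in this assay as "not active", with no number, so no step can be read from it to compound 3, which gives 5.36%. The compounds shown leave open whether swapping fluoro for hydrogen changes inhibition on this core at all. No measurement shown here helps to explain this result.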